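Three sulfonamides at the assay limit and a fourth awaiting measurement

The source may hold more compounds than are shown below. What is called first, only, known or untested is meant among the compounds shown, and "the series" means these compounds.

Compound 1 `O=S(=O)(Nc1ccc(-c2nc3ccccc3o2)cc1)c1ccc(Cl)s1` stands at a limit of the assay, > 63000 nM.
Compound 2 `Cc1ccccc1S(=O)(=O)Nc1ccc2oc(-c3ccccc3)nc2c1` stands at a limit of the assay, > 63000 nM.
Compound 3 `O=S(=O)(Nc1ccc2oc(-c3ccccc3)nc2c1)c1ccccc1F` stands at a limit of the assay, > 63000 nM.

All three were tested in an assay on isolated protein for inhibition of malate dehydrogenase, mitochondrial (Sus scrofa), with stated times of 45 min and 30 min (on this read-out higher numbers stand for weaker inhibition and lower numbers for stronger inhibition), and none of them gave a number. Compound 1 therefore stands at the edge of the measurable range, and since the other two sit at the same limit, no order among the three can be read. Within the data shown here, the one measured step between single-point neighbours, a step that the two limits leave unreadable from compound 2 to compound 3, a fluoro in place of methyl on an aromatic carbon, cannot be sized because the limit of > 63000 nM in this assay, at which 3 of the 3 values shown sit, holds both of its ends.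

Compound 4 `O=S(=O)(Nc1ccc(-c2nc3ccccc3o2)cc1)c1ccccc1F` differs from compound 1 by 2-fluorophenyl in place of 5-chlorothiophen-2-yl on a sulfonyl sulfur. Among the measured compounds shown here, no measured step bears on this exchange; the only measured step touches a different group and is itself unreadable. Since every measured value sits at the limit of > 63000 nM in this assay, at which 3 of the 3 values shown sit, the expectation for compound 4 is that it also yields no number, so the expected step from compound 1 to compound 4 in this assay, a step that the limit leaves unreadable from compound 1 to compound 4, is none beyond the scatter. Compound 4 is accordingly estimated at 100000 nM, within a range from 40000 nM to 300000 nM, and most likely reported only as a limit.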

Compound 4, half-maximal inhibitory concentration: > 63000 nM
Compound 4: no number, only a limit; the forecaster's own chance of this, stated with the estimate: 85%; the middle value lies beyond the limit too.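

In this assay compound 4 gives > 63000 nM as a limit and not a number. The exchange between compound 1 and compound 4 yields no readable step, because both ends sit at the same limit: the limit of > 63000 nM in this assay, at which 4 of the 4 values shown sit.
The compounds shown leave open whether any change on the sulfonyl sulfur or in the core gives a measurable value in this assay at all.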